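The compounds below may be only part of what the source reports. "The series", "measured", "known", "first", "only" and "open" are said of these compounds alone.

Of the compounds shown here, three in this set have been tested in a functional assay on HEp-2 cells (Homo sapiens) for inhibition; a lower number here means a stronger inhibitor, a higher number a weaker inhibitor. Compound 1 `CCC(C)C1NC(=O)N(C2CCCC2)C1=O` gives only a limit of the assay, > 100000 nM, and no number. Compound 2 `CCC(C)C(NC(=O)NO)C(=O)NCc1ccccc1` likewise gives a limit, > 100000 nM. For the measured compounds named here, compound 3 `CC(C)C1NC(=O)N(C2CCCC2)C1=O` is the one member of the set with a measured number, 98000 nM, and it therefore stands alone on the scale. The other two values sit at a limit of the assay (the limit of > 100000 nM in this assay, at which 2 of the 3 values shown sit). Going by the values given here, the step of an at least 1.0-fold lower number from compound 1 to compound 3 (0.00 log units; that floor lies within the scatter) is the single measured change of one group, and it lies within the scatter, so it points in no direction.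

Compound 4 `O=C1NC(c2ccccc2)C(=O)N1C1CCCC1` has not yet been measured. It differs from compound 3 by phenyl in place of isopropyl on a saturated ring carbon. Among the compounds with values here, no measured step puts an aromatic group at this position; the one known step, on a saturated chain carbon, was flat, and compound 3 itself sits close to the floor of this assay. For compound 4 the expected step of a 1.1-fold lower number from compound 3 to compound 4 (0.04 log units; within the scatter) is therefore small, within the scatter, with a considerable chance that only a limit is reported. Compound 4 is expected at 90000 nM, in a range from 20000 nM to 400000 nM.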

Compound 4, half-maximal inhibitory concentration: > 100000 nM
Compound 4 was reported as a limit; the forecaster's own chance of this, stated with the estimate: 55%; middle value at least 1.1-fold (0.04 log units) away from the limit.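

Swapping isopropyl for phenyl on the saturated ring carbon of the core gives an at least 1.0-fold higher number from compound 3 to compound 4 (0.00 log units; that floor lies within the scatter), so the first aromatic group seen at this position brings no gain in this assay that the data can show. For the compounds shown here, the earlier step touched only the end of the chain on this carbon, whereas this change replaces the whole group with one six-membered aromatic ring of carbon only, and even so the result stays at the edge of what the assay can read, leaving compound 3 as the only member with a measured number. The step from compound 1 to compound 4 cannot be read, and the set now gathers at one end of the scale: the limit of > 100000 nM in this assay, at which 3 of the 4 values shown sit.

The compounds shown leave open how large the step from isopropyl to phenyl really is, as its printed floor gives a direction no firmer than the scatter allows. They also leave open whether a group of another kind on this ring carbon, such as an amine, a carboxylic acid or a benzyl group, would give a clearly lower number than compound 3 does.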